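Geometry of the exocyclic double bond in a triazole series

This account rests on a few compounds, and the source may have more. Where it says the series, first, only, none or still open, it means among the compounds named here.

Compound 1 `CC(=O)OC[C@H]1O[C@@H](n2cc(CN3C(=O)/C(=C/c4ccc(C)cc4)c4ccccc43)nn2)[C@H](OC(C)=O)[C@@H](OC(C)=O)[C@@H]1OC(C)=O` in a functional assay on HeLa cells (Homo sapiens) for cytotoxicity, read by sulforhodamine B assay, with a stated time of 48 h (on this read-out higher numbers stand for weaker inhibition and lower numbers for stronger inhibition), gives 85600 nM. Compound 2 `CC(=O)OC[C@H]1O[C@@H](n2cc(CN3C(=O)/C(=C\c4ccc5ccccc5c4)c4ccccc43)nn2)[C@H](OC(C)=O)[C@@H](OC(C)=O)[C@@H]1OC(C)=O` in this assay is reported as > 100000 nM, which is a limit of the assay and not a number; this is the limit of > 100000 nM in this assay, at which 1 of the 2 values shown sits. Compound 3 `CC(=O)OC[C@H]1O[C@@H](n2cc(CN3C(=O)/C(=C/c4ccc5ccccc5c4)c4ccccc43)nn2)[C@H](OC(C)=O)[C@@H](OC(C)=O)[C@@H]1OC(C)=O` is the partner of compound 2 differing only in geometry: the two compounds have the same atoms and bonds and differ only in configuration as drawn: 1 of 6 stereo elements differ; a double bond is drawn Z in compound 2 and E in compound 3. Among the measured compounds shown here, no measured step of this kind is present, so the size of such a change cannot be read from the data. Compound 3 is expected to remain weak, with an estimated step of an at least 1.1-fold lower number from compound 2 to compound 3 (0.04 log units; that floor lies within the scatter). The estimate for compound 3 in this assay is 90000 nM, between 40000 nM and 200000 nM.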

Compound 3, half-maximal inhibitory concentration: > 100000 nM
Compound 3 ended at the assay's limit (the forecaster's own chance of this, stated with the estimate: 45%); middle value at least 1.1-fold (0.04 log units) from the limit.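

In this assay compound 3 is reported as > 100000 nM, which is a limit of the assay and not a number. The step from Z to E between compound 2 and compound 3 cannot be read, so neither geometry of the naphthalen-2-yl pair separates from the other: the limit of > 100000 nM in this assay, at which 2 of the 3 values shown sit. Naphthalen-2-yl in place of 4-methylphenyl gives an at least 1.1-fold higher number from compound 1 to compound 3 (0.06 log units; that floor lies within the scatter).

Open, going by these compounds, is whether double-bond geometry matters with 4-methylphenyl in place. Also open, on these data alone, is whether an amine or a carboxylic acid in place of naphthalen-2-yl would give a value clear of the limit.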